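Swapping chloro for iodo on the shared core

The compounds below may be only part of what the source reports. "The series", "measured", "known", "first", "only" and "open" are said of these compounds alone.

Measured in a functional assay on THP-1 cells (Homo sapiens) for inhibition, read by sulforhodamine B assay, with a stated time of 48 h, tested at 50 uM; on this read-out lower numbers stand for less inhibition of growth and higher numbers for more inhibition of growth at the one concentration tested:
Compound 1 `O=C1C(=O)N(CCCCn2cc(COc3cc(=O)oc4ccccc34)nn2)c2ccc(Cl)cc21` gives 71%
Compound 2 `COc1ccc2c(c1)C(=O)C(=O)N2CCCn1cc(COc2cc(=O)oc3ccccc23)nn1` gives 56%
Compound 3 `O=C1C(=O)N(CCCn2cc(COc3cc(=O)oc4ccccc34)nn2)c2ccccc21` gives 93%

On these numbers compound 1 stands second highest of three: compound 2 sits lower and compound 3 sits higher, and both gaps lie beyond the scatter. Compound 4 `O=C1C(=O)N(CCCCn2cc(COc3cc(=O)oc4ccccc34)nn2)c2ccc(I)cc21` differs from compound 1 by iodo in place of chloro on an aromatic carbon. For the measured compounds named here, the one measured step, a number 37 percentage points higher from compound 2 to compound 3 (beyond the scatter), concerns a methoxy and a hydrogen, not a halogen, so it does not bear on this change. Going by the values given here, no measured step shows how one halogen in place of another shifts the number, so compound 4 is expected to stay close to compound 1, a step of a number 1 percentage points lower from compound 1 to compound 4 (within the scatter), probably within the scatter. Compound 4 is estimated at 70%, with a range from 50% to 88%.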

Compound 4, percent growth inhibition at one concentration: 59%
Compound 4: middle estimate off by 11 percentage points, on the high side; low and high end bracket the measured number.
By their numbers in this assay, from the lowest: compounds 2 and 4 (each within the scatter of the next); then compound 1; then compound 3.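

The halogen on this aromatic carbon cannot be swapped freely: in this assay, iodo in place of chloro gives a number 12 percentage points lower from compound 1 to compound 4 (beyond the scatter). For the compounds shown here, this is the first halogen swap seen on the shared core, and it shows that replacing one heavy atom with another, with hydrogen-bond donors, acceptors and net charge all unchanged, can still move growth inhibition. Nothing available explains why the two halogens differ.

Still open, from the compounds shown here alone, is how a fluoro, a bromo or an amine on this same carbon would compare with chloro and iodo. Also open, going by these compounds, is whether iodo would still fall short of chloro with a longer chain.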